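This account rests on a few compounds, and the source may have more. Where it says the series, first, only, none or still open, it means among the compounds named here.

Working notes on the series. Compound 1 `Cc1ccc(/C=C/C(=O)O)c(OCCC2(C)CCc3c(C)c(O)c(C)c(C)c3O2)c1` and compound 2 `COc1ccc(/C=C/C(=O)O)c(OCCC2(C)CCc3c(C)c(O)c(C)c(C)c3O2)c1` share one core. Among the measured compounds shown here, in an assay on CHO cells for displacement of a labelled ligand from prostaglandin E2 receptor EP4 subtype (Mus musculus), read by scintillation counting (on this read-out lower numbers stand for stronger inhibition and higher numbers for weaker inhibition), compound 1 gives 2200 nM and compound 2 gives 920 nM; the single change between them reads a 2.4-fold lower number from compound 1 to compound 2 (0.38 log units; beyond the scatter). Compound 3 `O=C(O)/C=C/c1ccc(Cn2ccnc2)cc1OCCCOc1ccccc1` is built on a different scaffold. In this assay compound 3 reports only a limit, > 10000 nM. That value sits at the limit of > 10000 nM in this assay, at which 1 of the 3 values shown sits, so compound 3 cannot be placed against the two measured numbers more closely than that. Compound 4 `O=C(O)/C=C/c1ccc(Cn2ccnc2)cc1OCCCCOc1ccccc1` differs from compound 3 by phenoxymethyl in place of phenoxy on a saturated chain carbon, three bonds along the chain from an oxygen on an aromatic ring. For the measured compounds named here, the one measured step, a 2.4-fold lower number from compound 1 to compound 2 (0.38 log units; beyond the scatter), concerns a substituent exchange on another core, so it carries no information about lengthening a linker by one chain carbon; no measured step resembles the move from compound 3 to compound 4, and with compound 3 at a limit, not even a direction can be read from the data. The step that the limit leaves unreadable from compound 3 to compound 4 is therefore expected to be none beyond the scatter. Compound 4 is expected near 15000 nM, in a range from 3000 nM to 60000 nM, with a fair chance that the assay again reports only a limit.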

Compound 4, inhibition constant: > 10000 nM
Compound 4: no number, only a limit (the forecaster's own chance of this, stated with the estimate: 70%); the middle value does not contradict the limit.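

Compound 3 and compound 4 both report only a limit in this assay, so no step can be read between them: the limit of > 10000 nM in this assay, at which 2 of the 4 values shown sit.

The compounds shown leave open whether phenoxymethyl in place of phenoxy on that saturated chain carbon shifts the read-out at all, and in which direction.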